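Removing Trifluoromethyl from the Weakest Compound of the Series

This account rests on a few compounds, and the source may have more. Where it says the series, first, only, none or still open, it means among the compounds named here.

In a functional assay on MDA-MB-231 cells (Homo sapiens) for inhibition, read by MTT assay, with a stated time of 48 h (a higher number here means a weaker inhibitor, a lower number a stronger inhibitor), compound 3 `COc1cc(-c2nccn3cc(-c4ccc(C(F)(F)F)cc4)nc23)cc(OC)c1OC` gives > 10000 nM, which is a limit of the assay and not a number. Its two measured relatives differ from it only in one group on the same aromatic ring. With chloro at that place, compound 1 `COc1cc(-c2nccn3cc(-c4ccc(Cl)cc4)nc23)cc(OC)c1OC` gives 2090 nM. With hydrogen there, compound 2 `COc1cc(-c2nccn3cc(-c4ccccc4)nc23)cc(OC)c1OC` gives 364 nM.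

Compound 4 `COc1cc(-c2nccn3cc(-c4ccc(N)cc4)nc23)cc(OC)c1OC` carries amino in place of trifluoromethyl on an aromatic carbon. For the measured compounds named here, no measured compound has amino, so the three known steps offer only indirect guidance. Swapping chloro for hydrogen gives a 5.7-fold lower number from compound 1 to compound 2 (0.76 log units; beyond the scatter). Swapping chloro for trifluoromethyl gives an at least 4.7-fold higher number from compound 1 to compound 3 (0.67 log units; beyond the scatter), while swapping hydrogen for trifluoromethyl gives an at least 27-fold higher number from compound 2 to compound 3 (1.43 log units; beyond the scatter). In these three compounds, both groups tried in place of hydrogen raise the number, and none goes against this.

Amino has fewer heavy atoms than either chloro's neighbour trifluoromethyl or any larger group tested, so compound 2, at 364 nM, is taken as the closest guide. The expected step is therefore large and downward, an at least 16-fold lower number from compound 3 to compound 4 (1.22 log units; beyond the scatter). For compound 4 the estimated value is 600 nM, with an expected range from 120 nM to 3000 nM.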

Compound 4, half-maximal inhibitory concentration: 294 nM
For compound 4 the middle estimate is 2.0-fold (0.31 log units) above the measured one, and the stated range covers the measured number.
By their numbers in this assay, from the lowest: compounds 4 and 2 (each within the scatter of the next); then compound 1. At a limit, above all of these: compound 3.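

Until now, both groups tried in place of hydrogen on this aromatic carbon had raised the number, but in this assay amino does not, giving a 1.2-fold lower number from compound 2 to compound 4 (0.09 log units; within the scatter). A group can therefore stand at this place with no change beyond the scatter, and the two earlier substituents do not set the rule for every group: amino in place of chloro gives a 7.1-fold lower number from compound 1 to compound 4 (0.85 log units; beyond the scatter), and amino in place of trifluoromethyl gives an at least 34-fold lower number from compound 3 to compound 4 (1.53 log units; beyond the scatter). The last of these steps has only a lower bound, since compound 3 gives a limit and not a number: the limit of > 10000 nM in this assay, at which 1 of the 4 values shown sits.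

With only hydrogen, amino, chloro and trifluoromethyl at this place, the compounds shown leave open whether the number follows the heavy-atom count of the group or depends on what those atoms are. A hydroxyl or a methyl would compare amino with other small groups, while a methylamino or an acetamide would show whether the amino group tolerates added atoms.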